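This account rests on a few compounds, and the source may have more. Where it says the series, first, only, none or still open, it means among the compounds named here.

Three compounds that share a single core were measured in a functional assay on SW1573 cells (Homo sapiens) for inhibition, read by sulforhodamine B assay, with a stated time of 48 h; on this read-out lower numbers stand for stronger inhibition of growth and higher numbers for weaker inhibition of growth. Compound 1 `COC(=O)[C@@]1(C)CCC=C2[C@@H]1CC[C@@H](C)[C@]2(C)Cc1c[nH]c2c(C)cccc12` gives 7800 nM in this assay. Compound 2 `COC(=O)[C@@]1(C)CCC=C2[C@@H]1CC[C@@H](C)[C@]2(C)Cc1c(C)[nH]c2ccc(Cl)cc12` gives 14000 nM in this assay. Compound 3 `COC(=O)[C@@]1(C)CC[C@@H]2C3=C1CC[C@@H](C)[C@]3(C)C[C@@H]1c3cc(C)ccc3N[C@H]21` gives 23000 nM in this assay, the highest of the three numbers. Its gap to compound 2 lies within the scatter of repeated measurements, so nothing can be said about an order between these two. Its gap to compound 1 lies beyond the scatter, so compound 1 inhibits growth more strongly than compound 3 in this assay.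

Compound 4 `COC(=O)[C@@]1(C)CC[C@@H]2C3=C1CC[C@@H](C)[C@]3(C)C[C@@H]1c3cc(F)ccc3N[C@H]21` has not yet been measured. It differs from compound 3 in one place: fluoro in place of methyl on an aromatic carbon. For the measured compounds named here, no pair of measured compounds isolates this change, so no measured step size for it is at hand, and the three numbers above offer no guide to its direction. The expectation is therefore that the change from compound 3 to compound 4 brings no step beyond the scatter in this assay. In this assay compound 4 is expected to give about 20000 nM, within a range from 8000 nM to 50000 nM. The expected step of a 1.2-fold lower number from compound 3 to compound 4 (0.06 log units; within the scatter) is thus estimated to be small and without a clear direction.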

Compound 4, concentration for 50% growth inhibition: 27000 nM
The estimate for compound 4 lay 1.4-fold (0.13 log units) below the measured number; the range from low to high includes it.
By their numbers in this assay, from the lowest: compounds 1, 2, 3 and 4 (each within the scatter of the next, the first and the last beyond it).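

In this assay, for the compounds shown here, fluoro in place of methyl on this aromatic carbon brings a 1.2-fold higher number from compound 3 to compound 4 (0.07 log units; within the scatter) and so gives the first measured step for a change at this position. The step gives no order between the two compounds, so at this position a methyl and a fluoro, each a single heavy atom with no hydrogen-bond donor or acceptor, cannot be told apart on growth inhibition in this assay. Nothing at hand explains this result or says whether the two groups act alike on the cells.

The compounds shown leave open whether this position responds at all, since only two small groups have been compared there, and a bare hydrogen, a methoxy group, an amine or a carboxylic acid on the same aromatic carbon could still give a step beyond the scatter. Going by these compounds alone, they also leave open whether the same change would give a similar step on the core of compound 1 or compound 2, where no pair isolates it.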